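Swapping the amide group on compound 3

A few compounds are considered here, and "the series" means these few. Any claim that something is new, unique, unknown or untested is made for them only; others in the source may bear on it.

Measured in an ADME assay on microsomes from liver (Mus musculus, strain CD-1) for metabolic stability, read by LC-MS, tested at 2 uM; a higher number here means that the compound lasts longer, a lower number that the compound disappears faster:
- compound 1 `CN(C)S(=O)(=O)c1ccccc1Nc1cc(-c2ccc3ccn(C)c3c2)c2nccnc2c1`: 0.233 h
- compound 2 `Cn1ccc2ccc(-c3cc(Nc4cnccc4C(=O)NCc4cncnc4)cc4nccnc34)cc21`: 0.4 h
- compound 3 `Cn1cc(CNC(=O)c2ccncc2Nc2cc(-c3ccc4ccn(C)c4c3)c3nccnc3c2)cn1`: 0.267 h

Compound 3, at 0.267 h, lies within the usual scatter of both compound 1 and compound 2, so its place among these few numbers is not firmly fixed.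

The next compound is compound 4 `CN1CCC(NC(=O)c2ccncc2Nc2cc(-c3ccc4ccn(C)c4c3)c3nccnc3c2)CC1=O`, which has not yet been measured. Its difference from compound 3 is this: 1-methyl-2-oxopiperidin-4-yl in place of (1-methyl-1H-pyrazol-4-yl)methyl on an amide-type nitrogen. The change sits on an amide-type nitrogen, so a five-membered aromatic ring gives way to a six-membered non-aromatic ring.

Going by the values given here, only one measured step touches this part of the molecule: a 1.5-fold lower number from compound 2 to compound 3 (0.18 log units; within the scatter). That step exchanged one aromatic ring for another on the same saturated chain, and it stayed within the scatter. Among the compounds with values here, no measured compound carries the 1-methyl-2-oxopiperidin-4-yl group, so the data offer only a weak guide and give no firm direction.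

The expected size is therefore modest: a 1.3-fold higher number from compound 3 to compound 4 (0.12 log units; within the scatter) is the estimated step, and it stays within the scatter. In this assay compound 4 is estimated at 0.35 h, with an expected range of 0.17 h to 0.8 h.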

Compound 4, half-life: 0.717 h
Estimate against measurement, compound 4: 2.0-fold (0.31 log units) below, within the range that was stated.
By their numbers in this assay, from the lowest: compounds 1, 3, 2 and 4 (each within the scatter of the next, the first and the last beyond it).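

Placing 1-methyl-2-oxopiperidin-4-yl in place of (1-methyl-1H-pyrazol-4-yl)methyl on the amide-type nitrogen gives a 2.7-fold higher number from compound 3 to compound 4 (0.43 log units; beyond the scatter) in this assay, the first step at this position to go beyond the scatter. The earlier exchange of one aromatic ring for another on the same saturated chain did not do so, whereas this change removes that chain carbon and also replaces a five-membered aromatic ring with a six-membered non-aromatic ring. The comparison with the pyrimidin-5-yl compound is less firm: the step is a 1.8-fold higher number from compound 2 to compound 4 (0.25 log units; within the scatter), so the clear difference holds only against compound 3, and compound 4 cannot be ranked above compound 2.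

Nothing in the available data gives a reason for these results.

The compounds shown leave open whether the ring carbonyl or the loss of the chain carbon matters, which a plain 1-methylpiperidin-4-yl group or a (1-methyl-2-oxopiperidin-4-yl)methyl group on the same nitrogen could help separate. On these data alone, it is also open whether a ring is needed at all, a question that an open chain such as 2-methoxyethyl could address.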